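This account rests on a few compounds, and the source may have more. Where it says the series, first, only, none or still open, it means among the compounds named here.

Working notes on the series. In an ADME assay on isolated protein for inhibition of Dihydrofolate reductase (Homo sapiens), using NADPH (a lower number here means a stronger inhibitor, a higher number a weaker inhibitor), compound 1 `Nc1nc(N)c2nc(Nc3ccccc3)ccc2n1` gives 1530 nM. Compound 2 `CCCN(c1ccccc1)c1ccc2nc(N)nc(N)c2n1`, carrying propyl on the ring nitrogen, gives 1340 nM in this assay; the step of a 1.1-fold lower number from compound 1 to compound 2 (0.06 log units; within the scatter) lies within the scatter. Among the two numbers measured so far compound 2 stands alongside compound 1, the gap between them being within the scatter, so no order between the two is drawn.

Compound 3 `CC(C)N(c1ccccc1)c1ccc2nc(N)nc(N)c2n1` is not yet measured. It differs from compound 2 in one place: isopropyl in place of propyl on a nitrogen on an aromatic ring. Among the measured compounds shown here, the only measured step touching this nitrogen is a 1.1-fold lower number from compound 1 to compound 2 (0.06 log units; within the scatter), which sets propyl against hydrogen and stays within the scatter. For the measured compounds named here, no measured step sets isopropyl against propyl. On that basis, for compound 3 no step beyond the scatter is expected in this assay in either direction, the expected step being a 1.0-fold higher number from compound 2 to compound 3 (0.02 log units; within the scatter). Compound 3 is estimated at 1400 nM, with a range from 600 nM to 3300 nM.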

Compound 3, half-maximal inhibitory concentration: 1370 nM
Compound 3: middle estimate off by 1.0-fold (0.01 log units), on the high side; measured number inside the range.
By their numbers in this assay, from the lowest: compounds 2, 3 and 1 (each within the scatter of the next).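

Isopropyl and propyl carry the same carbons on this nitrogen on an aromatic ring, joined differently, and in this assay the change gives a 1.0-fold higher number from compound 2 to compound 3 (0.01 log units; within the scatter) and so separates nothing at this position. Hydrogen at the same nitrogen also stays unresolved from isopropyl, with a 1.1-fold lower number from compound 1 to compound 3 (0.05 log units; within the scatter) as the step, so hydrogen, propyl and isopropyl now form a set of three that shows no order in these numbers. No supporting measurement bears on this flat result.

Still open, on these data alone, is whether a longer chain, such as butyl or hexyl, would leave the scatter at this nitrogen. Equally open, as far as these compounds go, is whether a chain ending in an amine or a carboxylic acid would give a step beyond the scatter in either direction.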